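Vinyl to ethynyl: compound 2 and compound 3

The source may hold more compounds than are shown below. What is called first, only, known or untested is meant among the compounds shown, and "the series" means these compounds.

Values so far in a functional assay on HT-29 cells (Homo sapiens) for cytotoxicity, read by MTT assay, with a stated time of 48 h (a higher number here means a weaker inhibitor, a lower number a stronger inhibitor), for the two measured compounds
- compound 1 `CCCCCCC[C@@H](C/C=C/CCC(=O)N(C)C/C(=C\Cl)CC(=O)CC(=O)NC[C@H](O)CC(=O)OC)OC` gives 48000 nM
- compound 2 `C=CCCC[C@@H]1OC(=O)CNC(=O)[C@H](Cc2ccccc2)N(C)C(=O)[C@@H]2CCCN2C(=O)[C@H](Cc2ccccc2)N(C)C(=O)[C@H](C(C)C)NC(=O)C1(C)C` gives 24000 nM

In this assay compound 2 gives 24000 nM and compound 1 gives 48000 nM as its value, so the two lie within the usual scatter of each other and neither can be ranked. Compound 3 `C#CCCC[C@@H]1OC(=O)CNC(=O)[C@H](Cc2ccccc2)N(C)C(=O)[C@@H]2CCCN2C(=O)[C@H](Cc2ccccc2)N(C)C(=O)[C@H](C(C)C)NC(=O)C1(C)C` is not yet measured. Its change from compound 2 ethynyl in place of vinyl on a saturated chain carbon, three bonds along the chain from a saturated ring carbon puts ethynyl in place of vinyl on a saturated chain carbon, three bonds along the chain from a saturated ring carbon. Among the measured compounds shown here, no measured pair shows this exchange. No step beyond the scatter is expected in this assay for it, and the expectation rests on compound 2 at 24000 nM as the closest measured structure. The estimated 1.2-fold lower number from compound 2 to compound 3 (0.08 log units; within the scatter) stays inside that scatter. For compound 3 the expected value is 20000 nM with an estimated range from 8000 nM to 50000 nM in a measurement.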

Compound 3, half-maximal inhibitory concentration: 11000 nM
Compound 3: the middle estimate sits 1.8-fold (0.26 log units) above what was measured, within the range that was stated.
By their numbers in this assay, from the lowest: compound 3; then compounds 2 and 1 (each within the scatter of the next).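

In this assay, among the compounds shown here, ethynyl in place of vinyl on a saturated chain carbon, three bonds along the chain from a saturated ring carbon, gives a 2.2-fold lower number from compound 2 to compound 3 (0.34 log units; beyond the scatter), the first step that reads beyond the scatter. The position therefore responds to a change at the chain end even though the two groups match in heavy atoms, hydrogen-bond donors, hydrogen-bond acceptors and net charge, and differ in a triple bond against a double bond. No measurement at hand bears on what lies behind this modest step.

As far as these compounds go, the trend rests on a single pair, so whether the exchange holds on other cores stays open. Also open, from the compounds shown here alone, is how a nitrile, an amine or a longer chain at this place would compare with ethynyl.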